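Hydroxymethyl in Place of Dimethylamino: Estimating Compound 4

The compounds below may be only part of what the source reports. "The series", "measured", "known", "first", "only" and "open" are said of these compounds alone.

Measured compounds:
compound 1 `NS(=O)(=O)Oc1ccc2c(c1)CN(C(=O)c1cccc(N(Cc3ccccc3)Cc3ccco3)c1)CC2`: 90.5%
compound 2 `CN(C)CCCN(Cc1ccccc1)c1cccc(C(=O)N2CCc3ccc(OS(N)(=O)=O)cc3C2)c1`: 26%
compound 3 `CN(C)CCN(Cc1ccccc1)c1cccc(C(=O)N2CCc3ccc(OS(N)(=O)=O)cc3C2)c1`: 28.6%

In an assay on HEK293 cells for inhibition of Steryl-sulfatase (Homo sapiens), tested at 1 uM (a lower number here means a weaker effect, a higher number a stronger effect of the compound at the concentration tested), compound 1 gives 90.5%, compound 2 gives 26% and compound 3 gives 28.6%. Compound 3 stands second highest of the three numbers. Its nearest neighbour is compound 2, with a number 2.6 percentage points higher from compound 2 to compound 3 (within the scatter); its furthest is compound 1, with a number 61.9 percentage points lower from compound 1 to compound 3 (beyond the scatter).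

Compound 4 `NS(=O)(=O)Oc1ccc2c(c1)CN(C(=O)c1cccc(N(CCCO)Cc3ccccc3)c1)CC2` is the next step from compound 3. The difference is hydroxymethyl in place of dimethylamino on a saturated chain carbon, two bonds along the chain from a nitrogen on an aromatic ring.

Which measured steps bear on this? The step of a number 2.6 percentage points higher from compound 2 to compound 3 (within the scatter) shows that moving the dimethylamino group along the chain changes nothing beyond the scatter. The steps of a number 64.5 percentage points lower from compound 1 to compound 2 (beyond the scatter) and a number 61.9 percentage points lower from compound 1 to compound 3 (beyond the scatter) are large, but both concern furan-2-yl against a dimethylamino-bearing chain, not the swap of dimethylamino for hydroxymethyl. For the measured compounds named here, no measured pair covers that exchange directly. The expectation is therefore a step of modest size, more likely upward than downward, in this assay, written as a number 11.4 percentage points higher from compound 3 to compound 4 (beyond the scatter). For compound 4 the estimated value in this assay is 40%, with a range from 15% to 70%.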

Compound 4, a percentage reported as inhibition, at one concentration (the size of the read-out at that concentration, not a potency): 37.3%
The estimate for compound 4 lay 2.7 percentage points above the measured number, within the range that was stated.
By their numbers in this assay, from the lowest: compounds 2, 3 and 4 (each within the scatter of the next, the first and the last beyond it); then compound 1.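

In this assay, for the compounds shown here, hydroxymethyl in place of dimethylamino at this place on the chain gives a number 8.7 percentage points higher from compound 3 to compound 4 (within the scatter), and the comparison at the same chain length, hydroxy in place of dimethylamino three bonds along the chain from a nitrogen on an aromatic ring, gives a number 11.3 percentage points higher from compound 2 to compound 4 (beyond the scatter), so the end group of this chain has a measurable but modest bearing on the read-out in only one of the two comparisons. The earlier compounds carried only dimethylamino on this chain, whereas a number 53.2 percentage points lower from compound 1 to compound 4 (beyond the scatter) shows that the large gap to the furan-2-yl compound remains with a chain that has no dimethylamino at all, so that group alone does not account for the gap. No measurement offered here explains any of these steps.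

The compounds shown leave open whether the high number of compound 1 depends on the furan-2-yl ring itself or would also appear with another ring, such as thiophene or phenyl, on that carbon. They also leave open how a chain ending in a carboxylic acid or a methoxy group, or a longer chain ending in hydroxy, would fall relative to these values.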